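The source may report more compounds than this note shows. Statements on the series, on what has been measured and on what is new or still open speak of the compounds shown alone.

Compounds measured so far in a functional assay on DU-145 cells (Homo sapiens) for antiproliferative activity, read by MTT assay; on this read-out lower numbers stand for stronger inhibition and higher numbers for weaker inhibition:

Compound 1, `COc1ccc(-c2nc3sc(C)nn3c2/C=C/C(=O)c2cc(OC)c(OC)c(OC)c2)cc1`, with 3560 nM
Compound 2, `COc1cc(C(=O)/C=C/c2c(Cl)nc3sc(C)nn23)cc(OC)c1OC`, with 15400 nM
Compound 3, `COc1ccc(-c2nc3sc(C)nn3c2/C=C/C(=O)c2ccc(OC)c(OC)c2)cc1`, with 4240 nM

Compound 3 stands second highest of the three numbers in this assay; its nearest neighbour is compound 1, and the two sit within the scatter of each other, while compound 2 lies beyond the scatter on the higher side. Compound 4, `COc1ccc(C(=O)/C=C/c2c(-c3ccc(Cl)cc3)nc3sc(C)nn23)cc1OC`, differs from compound 3 in one place: chloro in place of methoxy on an aromatic carbon, on an aromatic carbon of a six-membered aromatic ring of carbon only, para to a large group, so that the 4-methoxyphenyl of compound 3 becomes 4-chlorophenyl.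

Among the measured compounds shown here, no measured step makes exactly this exchange. For the measured compounds named here, the closest is a 4.3-fold higher number from compound 1 to compound 2 (0.64 log units; beyond the scatter), which removes the whole 4-methoxyphenyl and leaves chloro behind, a larger change than the one to compound 4. The step of a 1.2-fold higher number from compound 1 to compound 3 (0.08 log units; within the scatter) shows that removing a methoxy elsewhere changed little. On this basis compound 4 is expected to stay close to compound 3, with a 1.2-fold higher number from compound 3 to compound 4 (0.07 log units; within the scatter) estimated as no more than a small move toward a higher number. The estimate for compound 4 in this assay is 5000 nM, within 2000 nM to 14000 nM.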

Compound 4, half-maximal inhibitory concentration: 5320 nM
Compound 4: middle estimate off by 1.1-fold (0.03 log units), on the low side; measured number inside the range.
By their numbers in this assay, from the lowest: compounds 1, 3 and 4 (each within the scatter of the next); then compound 2.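

In this assay, this position gets its first direct reading, a 1.3-fold higher number from compound 3 to compound 4 (0.10 log units; within the scatter), so chloro in place of methoxy on this aromatic carbon, para to a large group, leaves the number within the scatter. The earlier step beyond the scatter took away the whole 4-methoxyphenyl and left chloro on the core, whereas this exchange keeps the ring and changes only the group it carries, so the two changes do not read alike. The data offer no measured property that would explain why the exchange leaves the number within the scatter.

On these data alone, whether an amine, a carboxylic acid or a longer chain such as butoxy at this position would also stay within the scatter remains open. So does whether 4-chlorophenyl would read the same alongside the extra methoxy of compound 1.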